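Trimming one carbon from the best compound so far

This account rests on a few compounds, and the source may have more. Where it says the series, first, only, none or still open, it means among the compounds named here.

compound 1 `Cc1cc(C)cc(SCc2ccc(/C=C/C(=O)Nc3ccccc3N)cc2)c1` gives 4.2%
compound 2 `Nc1ccccc1NC(=O)/C=C/c1ccc(CSc2ccc(Cl)cc2)cc1` gives 3.27%
compound 3 `CCc1ccc(SCc2ccc(C(=O)Nc3ccccc3N)cc2)cc1` gives 79.1%

In a functional assay on HCT-116 cells (Homo sapiens) for inhibition, read by CCK-8 assay, with a stated time of 72 h, tested at 8 uM (on this read-out lower numbers stand for less inhibition of growth and higher numbers for more inhibition of growth at the one concentration tested), compound 3 stands highest of the three, well clear of compound 1 and compound 2. Compound 4 `Cc1ccc(SCc2ccc(C(=O)Nc3ccccc3N)cc2)cc1` has not yet been measured. It shares the core of compound 3, with one change: hydrogen in place of methyl on a saturated chain carbon bound to an aromatic carbon, so 4-ethylphenyl becomes 4-methylphenyl. Among the compounds with values here, the one measured step that swaps a group on a sulfur is a number 0.9 percentage points lower from compound 1 to compound 2 (within the scatter) and it is only a loose guide, as both of its compounds have a different core and low values. The expected change is a number 5.1 percentage points lower from compound 3 to compound 4 (within the scatter) and it is estimated to stay small. For compound 4 the estimate is 74% with an expected range from 50% to 92% in this read-out.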

Compound 4, percent growth inhibition at one concentration: 84%
Beside the measured number, compound 4's estimate is 10 percentage points below it; low and high end bracket the measured number.
By their numbers in this assay, from the lowest: compounds 2 and 1 (each within the scatter of the next); then compounds 3 and 4 (each within the scatter of the next).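

In this assay, going from 4-ethylphenyl to 4-methylphenyl gives a number 4.9 percentage points higher from compound 3 to compound 4 (within the scatter) and so removing this methyl from a saturated chain carbon bound to an aromatic carbon leaves growth inhibition unchanged within the scatter. Within the data shown here, the only earlier step, a swap of the group on sulfur, lay in a different core and among low values, whereas this one shows that a high value can hold through a small trim. No available evidence accounts for this result. Going by these compounds, whether a longer chain such as propyl, or an amine or a carboxylic acid in this place, would keep the value remains open.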